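Ester addition on a weakly cytotoxic dimeric sesquiterpene lactone core

This account rests on a few compounds, and the source may have more. Where it says the series, first, only, none or still open, it means among the compounds named here.

Measured so far:
compound 1, `C=C1C(=O)O[C@@H]2[C@@H]3[C@@]4(C=C[C@@]3(C)[C@]3(C4)C(=O)O[C@@H]4[C@H]5C(C)=CC[C@H]5[C@](C)(O)C[C@H](O)[C@H]43)[C@](C)(O)CC[C@@H]12`, > 10000 nM
compound 2, `C/C=C(\C)C(=O)O[C@H]1C[C@@](C)(O)[C@]23C=C[C@](C)([C@@H]2[C@H]2OC(=O)[C@@H](C)[C@@H]21)[C@]1(C3)C(=O)O[C@@H]2[C@H]3C(C)=CC[C@H]3[C@](C)(O)C[C@H](O)[C@H]21`, 9200 nM

Compound 1 carries the shared core with a free hydrogen on the saturated ring carbon of its seven-membered ring. In a functional assay on HONE1 cells for cytotoxicity against HONE1 cell line (Homo sapiens), read by MTT assay, with a stated time of 48 h (a lower number here means a stronger inhibitor, a higher number a weaker inhibitor), compound 1 reaches only the limit of the assay, > 10000 nM, and no number is known for it. Compound 2 differs from it in more than one place, so the two are not joined by a single step; in this assay compound 2 gives 9200 nM, a measured number. Where compound 1 stands is therefore told only by the limit of > 10000 nM in this assay, at which 1 of the 2 values shown sits.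

Compound 3, `C=C1C(=O)O[C@H]2[C@H]1[C@@H](OC(=O)/C(C)=C/C)C[C@@](C)(O)[C@]13C=C[C@](C)([C@H]21)[C@]1(C3)C(=O)O[C@@H]2[C@H]3C(C)=CC[C@H]3[C@](C)(O)C[C@H](O)[C@H]21`, is compound 1 with ((1-methylprop-1-en-1-yl)carbonyl)oxy in place of hydrogen on a saturated ring carbon. Among the measured compounds shown here, no measured step matches this change, and the two values at hand both lie near the edge of the assay. The step from compound 1 to compound 3 is thus expected to be small in this assay, if anything toward a stronger inhibitor, and may well stay within the scatter. Compound 3 is accordingly estimated at 8000 nM, between 3000 nM and 20000 nM, which corresponds to an expected step of an at least 1.2-fold lower number from compound 1 to compound 3 (0.09 log units; that floor lies within the scatter).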

Compound 3, half-maximal inhibitory concentration: 7500 nM
Beside the measured number, compound 3's estimate is 1.1-fold (0.03 log units) above it; the range from low to high includes it.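

In this assay, among the compounds shown here, putting ((1-methylprop-1-en-1-yl)carbonyl)oxy in place of hydrogen on a saturated ring carbon of the seven-membered ring gives the first step that can be read at this position: an at least 1.3-fold lower number from compound 1 to compound 3 (0.12 log units; that floor lies within the scatter). For compound 1, > 10000 nM is a limit of the assay and not a number, so the step is known only as a floor, and its true size may be larger: the limit of > 10000 nM in this assay, at which 1 of the 3 values shown sits. Compound 3 gives 7500 nM, a measured number, which shows that this ester on the core of compound 1 yields a value that can be read but does not by itself take the compound far from the edge of this assay.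

The compounds shown leave open whether a shorter acetyloxy group, a longer acyl chain or an amine on this same ring carbon would produce a step beyond the scatter. They also leave open how much of the activity depends on the double bond of this ester, since its saturated counterpart does not appear among them.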